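Benzyl substituent change from compound 2 to compound 4

The source may hold more compounds than are shown below. What is called first, only, known or untested is meant among the compounds shown, and "the series" means these compounds.

The series shares one core. Compound 1 `CCCSc1nc(N/N=C/c2ccccc2Cl)c2nnn(Cc3ccccc3)c2n1`, compound 2 `CCCSc1nc(N/N=C(\C)c2ccccc2O)c2nnn(Cc3ccccc3Cl)c2n1` and compound 3 `CCCSc1nc(N/N=C/c2cccs2)c2nnn(Cc3ccccc3)c2n1` differ in the group on the carbon with a double bond to nitrogen and in the benzyl group. In a functional assay on ECa-109 cells (Homo sapiens) for antiproliferative activity, read by MTT assay, with a stated time of 72 h (a lower number here means a stronger inhibitor, a higher number a weaker inhibitor), compound 1 gives 6180 nM. Compound 3 gives only a limit of the assay, > 64000 nM. Going by the values given here, the single step with a number attached is an at least 10-fold higher number from compound 1 to compound 3 (1.01 log units; beyond the scatter). Compound 2 likewise gives only a limit, > 64000 nM, so it stands without a number among the weaker members. Two of the three values sit at the limit of > 64000 nM in this assay, at which 2 of the 3 values shown sit.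

Compound 4 `CCCSc1nc(N/N=C(\C)c2ccccc2O)c2nnn(Cc3ccc(F)cc3)c2n1` differs from compound 2 by 4-fluorophenyl in place of 2-chlorophenyl on a saturated chain carbon bound to an aromatic nitrogen. Among the compounds with values here, no measured step touches the benzyl group; the only recorded step lies on the carbon with a double bond to nitrogen, a different place, so nothing here fixes the size or direction of a change in this assay for this substitution. The expectation rests on compound 2 alone. Compound 4 is expected to give about 60000 nM, within 15000 nM to 200000 nM, and most likely again only a limit. The expected step of an at least 1.0-fold lower number from compound 2 to compound 4 (0.02 log units; that floor lies within the scatter) is thus essentially none beyond the scatter.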

Compound 4, half-maximal inhibitory concentration: 21900 nM
Compound 4: the middle estimate sits 2.7-fold (0.44 log units) above what was measured; the range from low to high includes it.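

In this assay, going by these compounds alone, 4-fluorophenyl in place of 2-chlorophenyl on a saturated chain carbon bound to an aromatic nitrogen gives an at least 2.9-fold lower number from compound 2 to compound 4 (0.46 log units; beyond the scatter), the first measured step at this place. The group on the carbon with a double bond to nitrogen is the same in both compounds, so the benzyl group alone can shift the read-out beyond the scatter. The size of the step is only a floor, because compound 2 gives a limit of the assay and no number: the limit of > 64000 nM in this assay, at which 2 of the 4 values shown sit.

The step replaces 2-chlorobenzyl with 4-fluorobenzyl, so the compounds shown cannot separate the identity of the halogen from where it sits. A 4-chlorobenzyl or 2-fluorobenzyl pair with this same group on the carbon with a double bond to nitrogen would separate them, and a benzyl group carrying an amine or a carboxylic acid remains an open question.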